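The source may hold more compounds than are shown below. What is called first, only, known or untested is meant among the compounds shown, and "the series" means these compounds.

Working notes on the thiosemicarbazide series.

Compound 1 `N/C(=N\NC(=S)N1CCCC1)c1ccc(F)cn1` and compound 2 `N/C(=N\NC(=S)N1CCCCC1)c1ccccn1` share the same core and differ in two places at once, the ring on the thiocarbonyl carbon and the substitution of the pyridine. In a functional assay on A-431 cells (Homo sapiens) for cytotoxicity, read by MTT assay, with a stated time of 72 h, tested at 100 uM (on this read-out lower numbers stand for less inhibition of growth and higher numbers for more inhibition of growth at the one concentration tested), compound 1 gives 85.6%. In this assay compound 2 gives 85.6%. Compound 2 stands level with compound 1 at the digits shown; the two values lie within the scatter of each other, so no order between them can be read from these numbers. Going by the values given here, no single-point step between measured compounds exists in this set.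

Compound 3 `N/C(=N\NC(=S)N1CCCC1)c1ccccn1` is the next member to be measured. Relative to compound 2, the change is pyrrolidin-1-yl in place of piperidin-1-yl on a thiocarbonyl carbon. The pyridine of compound 2 is kept unchanged. Both ring sizes on the thiocarbonyl carbon have already been seen to sit at the same level, so the expected step in this assay is none beyond the scatter, with the estimated step from compound 2 to compound 3 being a number 1.6 percentage points lower from compound 2 to compound 3 (within the scatter). Compound 3 is therefore expected to give about 84%, with a range from 72% to 94%.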

Compound 3, percent growth inhibition at one concentration: 83.8%
Estimate against measurement, compound 3: 0.2 percentage points above; low and high end bracket the measured number.
By their numbers in this assay, from the lowest: compounds 3, 1 and 2 (each within the scatter of the next).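

Compound 3 breaks the two-place comparison of compound 1 and compound 2 into two single-place steps. In this assay, pyrrolidin-1-yl in place of piperidin-1-yl on a thiocarbonyl carbon gives a number 1.8 percentage points lower from compound 2 to compound 3 (within the scatter), while hydrogen in place of fluoro on an aromatic carbon gives a number 1.8 percentage points lower from compound 1 to compound 3 (within the scatter). Each place, taken singly, therefore stays within the scatter, so the match between compound 1 and compound 2 no longer rests only on a comparison in which two places differ, and no measurement at hand bears on why these replacements leave the read-out within the scatter.

The compounds shown leave open whether a morpholin-4-yl ring or an open-chain dimethylamino group on the thiocarbonyl carbon would stay within the scatter of these values, and whether chloro or methoxy on the aromatic carbon would do the same. From the compounds shown here alone, all three compounds are also read at a single concentration, so any separation among them at other concentrations remains unknown.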